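A few compounds are considered here, and "the series" means these few. Any claim that something is new, unique, unknown or untested is made for them only; others in the source may bear on it.

Compound 1, `Oc1cc(C(F)(F)F)ccc1-c1nc(-c2ccccc2O)n(-c2ccc(C(F)(F)F)cc2)n1`, gives 90.5% in a functional assay on PC-12 cells (Rattus norvegicus) for cytotoxicity, read by MTT assay, with stated times of 2 h and 24 h, tested at 5 uM; a higher number here means a stronger effect of the compound at the concentration tested, a lower number a weaker effect. Compound 2, `COc1ccc(-n2nc(-c3ccc(C(F)(F)F)cc3O)nc2-c2ccccc2O)cc1`, gives 86.6% in this assay, and compound 3, `Oc1cc(C(F)(F)F)ccc1-c1nc(-c2ccccc2O)n(-c2cccc(C(F)(F)F)c2)n1`, gives 92.2% in this assay. The change from compound 1 to compound 2 is methoxy in place of trifluoromethyl on an aromatic carbon, and it made a number 3.9 percentage points lower from compound 1 to compound 2 (within the scatter). Compound 1 and compound 3 have the same atoms joined differently, (3-(trifluoromethyl)phenyl in place of 4-(trifluoromethyl)phenyl on an aromatic nitrogen), a difference that made a number 1.7 percentage points higher from compound 1 to compound 3 (within the scatter); between them, a number 5.6 percentage points higher from compound 2 to compound 3 (within the scatter). All three values lie within the scatter of one another, so no order among them can be read.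

Compound 4, `COc1cccc(-n2nc(-c3ccc(C(F)(F)F)cc3O)nc2-c2ccccc2O)c1`, has not yet been measured in this assay. It differs from compound 3 by methoxy in place of trifluoromethyl on an aromatic carbon. This is the same kind of change as that from compound 1 to compound 2, but not the same: in compound 2 the methoxy stands para to a large group, in compound 4 it stands meta to a large group, and the cores differ as told above. Because a number 3.9 percentage points lower from compound 1 to compound 2 (within the scatter) stayed within the scatter, the step from compound 3 to compound 4 is expected to be small as well, about a number 3.7 percentage points lower from compound 3 to compound 4 (within the scatter). Compound 4 is therefore estimated at 88.5%, with a likely range from 80% to 95%.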

Compound 4, a percentage reported as activity, at one concentration (the size of the read-out at that concentration, not a potency): 96.8%
Compound 4: the middle estimate sits 8.3 percentage points below what was measured; measured number outside the range, above it.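

Among these compounds, on the two cores, the exchange of trifluoromethyl for methoxy in this assay gave steps that cannot be told apart: the same change on two cores in this assay, a number 3.9 percentage points lower (within the scatter) from compound 1 to compound 2 and a number 4.6 percentage points higher (within the scatter) from compound 3 to compound 4, 8.5 percentage points apart, within the scatter of two such steps The new step, a number 4.6 percentage points higher from compound 3 to compound 4 (within the scatter), therefore shows only that this exchange stayed within the scatter on both cores; the opposite signs of the two steps carry no weight, and two pairs cannot show that the same would hold on any further core. Of the other new steps, a number 6.3 percentage points higher from compound 1 to compound 4 (within the scatter) adds no readable difference, while a number 10.2 percentage points higher from compound 2 to compound 4 (beyond the scatter) is a modest one that belongs to a different change, 3-methoxyphenyl for 4-methoxyphenyl, and so says nothing about carrying the exchange between cores.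

The compounds shown leave open what an amine, a carboxylic acid or a chain longer than methoxy would do on this phenyl ring. Each read-out comes from a single concentration and tells only of a stronger or weaker effect at that concentration.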